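The source may hold more compounds than are shown below. What is called first, only, known or untested is meant among the compounds shown, and "the series" means these compounds.

Compound 1, `C[C@@H]1O[C@@]1(C)C(=O)C[C@@H]1[C@@]2(C)[C@@H](O)CCC(C)(C)[C@]2(O)CC[C@@]1(C)O`, in a functional assay on MDA-MB-231 cells (Homo sapiens) for cytotoxicity, read by MTT assay, with a stated time of 24 h (a lower number here means a stronger inhibitor, a higher number a weaker inhibitor), gives > 10000 nM, which is a limit of the assay and not a number. Compound 2, `C[C@@H]1O[C@@]1(C)C(=O)C[C@H]1[C@](C)(O)CC[C@@]2(O)C(C)(C)CCC[C@]12C`, in this assay gives > 10000 nM, again a limit. Compound 3, `C/C=C(\C)C(=O)C[C@@H]1[C@@]2(C)[C@@H](O)CCC(C)(C)[C@]2(O)CC[C@@]1(C)O`, in this assay gives > 10000 nM, also a limit.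

The change from compound 1 to compound 2 is hydrogen in place of hydroxy on a saturated ring carbon. Its step is a step that the two limits leave unreadable from compound 1 to compound 2, unreadable because of the limit of > 10000 nM in this assay, at which 3 of the 3 values shown sit. The two cores differ by 1-methylprop-1-en-1-yl in place of 2,3-dimethyloxiran-2-yl on a carbonyl carbon, with the step that the two limits leave unreadable from compound 1 to compound 3, which the same limits leave unreadable.

Compound 4, `C/C=C(\C)C(=O)C[C@H]1[C@](C)(O)CC[C@@]2(O)C(C)(C)CCC[C@]12C`, is not yet measured. It differs from compound 3 by hydrogen in place of hydroxy on a saturated ring carbon, the same change as from compound 1 to compound 2, since the surroundings of the place are described in the same words. Because (the limit of > 10000 nM in this assay, at which 3 of the 3 values shown sit), every measured compound sits at the limit, so there is no readable step to carry over; compound 3 gives only a limit. The expectation for compound 4 is therefore that it too stays weak, with an estimated step that the limit leaves unreadable from compound 3 to compound 4. Compound 4 is estimated at 20000 nM, expected between 8000 nM and 60000 nM, most likely reported as a limit again.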

Compound 4, half-maximal inhibitory concentration: > 10000 nM
Compound 4: only a limit was reported; the forecaster's own chance of this, stated with the estimate: 85%; the middle value does not contradict the limit.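

No new step can be read for compound 4 against compound 3 or compound 2, because every compound shown gives the same limit rather than a number: the limit of > 10000 nM in this assay, at which 4 of the 4 values shown sit. Whether hydrogen in place of hydroxy, or 1-methylprop-1-en-1-yl in place of 2,3-dimethyloxiran-2-yl, changes the strength of these compounds in this assay at all stays open.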